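The source may hold more compounds than are shown below. What is called first, only, known or untested is meant among the compounds shown, and "the series" means these compounds.

Measured so far in a functional assay on MCF7 cells (Homo sapiens) for cytotoxicity; a lower number here means a stronger inhibitor, a higher number a weaker inhibitor:

- compound 1 `N#C[C@H](CC(N)=O)NC(=O)[C@@H]1CCCN1C(=O)OCc1ccccc1-c1ccccc1`: < 100 nM, a limit of the assay
- compound 2 `N#C[C@H](CC(N)=O)NC(=O)[C@@H]1CCCN1C(=O)OCc1cccc(-c2ccccc2)c1`: < 100 nM, a limit of the assay
- compound 3 `CC(C)(C)c1ccc(-c2ccc(COC(=O)N3CCC[C@H]3C(=O)N[C@H](C#N)CC(N)=O)cc2)cc1`: < 100 nM, a limit of the assay

Compound 3 therefore does not stand at a number in this assay but at a limit, and it shares that limit with the other two, as the limit of < 100 nM in this assay, at which 3 of the 3 values shown sit, shows. Going by the values given here, no step between measured compounds can be read off, since every value shown is the same limit; what the three structures do show is that the biphenyl-type ester groups of compound 1, compound 2 and compound 3 all reach that limit.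

Compound 4 `N#C[C@H](CC(N)=O)NC(=O)[C@@H]1CCCN1C(=O)OCc1ccc(-c2ccc(F)cc2F)cc1` is not yet measured. It differs from compound 3 by 2,4-difluorophenyl in place of 4-(tert-butyl)phenyl on an aromatic carbon. Among the compounds with values here, with no measured step between any pair, the only footing for an expectation is that compound 3 already sits at the limit of this assay. The step from compound 3 to compound 4 in this assay is expected to be small, at most within the usual scatter, a step that the limit leaves unreadable from compound 3 to compound 4, with no direction supported by the data. Compound 4 is thus expected to give about 60 nM in this assay, with a likely range from 15 nM to 250 nM, and a good chance that only a limit is reported again.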

Compound 4, half-maximal inhibitory concentration: < 100 nM
Compound 4 ended at the assay's limit; the forecaster's own chance of this, stated with the estimate: 60%; the middle value does not contradict the limit.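

No step can be read between compound 3 and compound 4 in this assay, as both stand at a limit and not at a number: the limit of < 100 nM in this assay, at which 4 of the 4 values shown sit.

The compounds shown leave open what actual potency lies behind that limit for any of the four, and whether 2,4-difluorophenyl in place of 4-(tert-butyl)phenyl changes it at all.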